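The source may hold more compounds than are shown below. What is called first, only, known or untested is meant among the compounds shown, and "the series" means these compounds.

Measured so far in a functional assay on A549 cells (Homo sapiens) for cytotoxicity, read by MTT assay, with a stated time of 48 h; a higher number here means a weaker inhibitor, a lower number a stronger inhibitor: compound 1 `CC(C)(C)c1ccc(Cn2nc(-c3ccccc3)cc2C(=O)N/N=C/c2ccccc2O)cc1` gives 6230 nM; compound 2 `CC(C)(C)c1ccc(Cn2nc(-c3ccc(Cl)cc3)cc2C(=O)N/N=C/c2ccccc2O)cc1` gives 3390 nM; compound 3 `COc1ccc(-c2cc(C(=O)N/N=C/c3ccccc3O)n(Cc3ccccc3)n2)cc1` gives 7420 nM.

Compound 3 has the highest number of the three; compound 1 sits within the scatter of it, compound 2 beyond it. Compound 4 `COc1ccc(-c2cc(C(=O)N/N=C/c3ccccc3O)n(Cc3ccc(C(C)(C)C)cc3)n2)cc1` carries the change (tert-butyl in place of hydrogen on an aromatic carbon), on an aromatic carbon of a six-membered aromatic ring of carbon only, para to a large group. Among the compounds with values here, no measured step covers this change: the only single step, a 1.8-fold lower number from compound 1 to compound 2 (0.26 log units; within the scatter), concerns chloro on the other aromatic ring. Compound 1 and compound 3 differ in two places and lie within the scatter of each other. No step beyond the scatter is therefore expected in this assay, and the estimated step is a 1.2-fold lower number from compound 3 to compound 4 (0.09 log units; within the scatter). Compound 4 is expected at 6000 nM, range 3000 nM to 12000 nM.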

Compound 4, half-maximal inhibitory concentration: 4890 nM
Beside the measured number, compound 4's estimate is 1.2-fold (0.09 log units) above it; measured number inside the range.
By their numbers in this assay, from the lowest: compounds 2, 4, 1 and 3 (each within the scatter of the next, the first and the last beyond it).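

Benzyl to 4-(tert-butyl)benzyl can now be read directly in this assay (a 1.5-fold lower number from compound 3 to compound 4 (0.18 log units; within the scatter)), so tert-butyl at this position produces no step beyond the scatter. With 4-(tert-butyl)benzyl held, the other aromatic ring also shows no step beyond the scatter, for methoxy in place of chloro (a 1.4-fold higher number from compound 2 to compound 4 (0.16 log units; within the scatter)) or methoxy in place of hydrogen (a 1.3-fold lower number from compound 1 to compound 4 (0.11 log units; within the scatter)). No evidence on a cause is available for these steps.

Open, on these data alone, is whether an amine or a carboxylic acid in place of tert-butyl at this position would give a step beyond the scatter.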